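The source may report more compounds than this note shows. Statements on the series, on what has been measured and on what is new or still open speak of the compounds shown alone.

Compound 2 `C=C1C(=O)O[C@H]2[C@H]1CC/C(COC(=O)NCCN1CCCC1)=C\CC[C@@]1(C)O[C@@H]21` gives 1780 nM in a functional assay on NCI-H522 cells (Homo sapiens) for inhibition (a lower number here means a stronger inhibitor of growth, a higher number a weaker inhibitor of growth), and compound 1 `C=C1C(=O)O[C@H]2[C@H]1CC/C(COC(=O)N1CCC(F)(F)CC1)=C\CC[C@@]1(C)O[C@@H]21` gives 1250 nM, so these two values cannot be told apart. Compound 3 `C=C1C(=O)O[C@H]2[C@H]1CC/C(COC(=O)Nc1n[nH]c(SC)n1)=C\CC[C@@]1(C)O[C@@H]21` carries 5-(methylsulfanyl)-1H-1,2,4-triazol-3-yl in place of 2-(pyrrolidin-1-yl)ethyl on an amide-type nitrogen. Among the measured compounds shown here, only one measured step bears on this change, a 1.4-fold higher number from compound 1 to compound 2 (0.15 log units; within the scatter), and no measured compound carries an aromatic ring at this place, so the evidence is thin. The expected result in this assay is no shift beyond the scatter, with an estimated 1.4-fold lower number from compound 2 to compound 3 (0.14 log units; within the scatter). Compound 3 is expected at 1300 nM, within an estimated range of 500 nM to 3400 nM.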

Compound 3, concentration for 50% growth inhibition: 1260 nM
Estimate against measurement, compound 3: 1.0-fold (0.01 log units) above; measured number inside the range.
By their numbers in this assay, from the lowest: compounds 1, 3 and 2 (each within the scatter of the next).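

Among the compounds shown here, with an aromatic ring on the amide-type nitrogen for the first time, this assay gives a 1.4-fold lower number from compound 2 to compound 3 (0.15 log units; within the scatter) and a 1.0-fold higher number from compound 1 to compound 3 (0.00 log units; within the scatter). Thus 5-(methylsulfanyl)-1H-1,2,4-triazol-3-yl, 2-(pyrrolidin-1-yl)ethyl and 4,4-difluoropiperidin-1-yl, which share few features, all leave the number within the scatter. No measurement available here accounts for this result. Still open, as far as these compounds go, is whether a carboxylic acid or a longer alkyl chain at this place would shift the number beyond the scatter. Also open, from the compounds shown here alone, is what happens if a phenyl ring replaces the triazole.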